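Fluoro to trifluoromethyl in a thyroid receptor beta series

The source may hold more compounds than are shown below. What is called first, only, known or untested is meant among the compounds shown, and "the series" means these compounds.

Compound 1 `CN(Cc1ccccc1)C(=O)C1CCN(C(=O)c2ccc(S(C)(=O)=O)c([N+](=O)[O-])c2)CC1` — > 60000 nM
Compound 2 `CN(CC(=O)N1CCN(c2ccc(F)cc2)CC1)C(=O)c1ccc(S(C)(=O)=O)c([N+](=O)[O-])c1` — > 60000 nM

In an assay on isolated protein for inhibition of thyroid hormone receptor beta (Homo sapiens), read by fluorescence polarization (on this read-out higher numbers stand for weaker inhibition and lower numbers for stronger inhibition), compound 1 gives > 60000 nM, which is a limit of the assay and not a number. In this assay compound 2 gives > 60000 nM, again a limit rather than a number. Compound 2 therefore stands nowhere distinct within the shown numbers: both values sit at the same limit (the limit of > 60000 nM in this assay, at which 2 of the 2 values shown sit), so no order between compound 1 and compound 2 can be drawn.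

Compound 3 `CN(CC(=O)N1CCN(c2ccc(C(F)(F)F)cc2)CC1)C(=O)c1ccc(S(C)(=O)=O)c([N+](=O)[O-])c1` follows from compound 2 by trifluoromethyl in place of fluoro on an aromatic carbon. With both shown values at the limit, the expected step that the limit leaves unreadable from compound 2 to compound 3 is none beyond the scatter, and compound 3 is expected to remain at the limit of this assay. Compound 3 is estimated at 80000 nM, with a range from 30000 nM to 300000 nM. The measured value of compound 3 in this assay is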

Compound 3, half-maximal inhibitory concentration: > 60000 nM
Compound 3: a limit, no number (the forecaster's own chance of this, stated with the estimate: 85%); the middle value is on the limit's open side.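

The exchange of fluoro for trifluoromethyl between compound 2 and compound 3 gives no readable step in this assay, as both values are limits and not numbers. The compounds shown leave open any order among compound 1, compound 2 and compound 3, and what would bring a value inside the measurable range: the limit of > 60000 nM in this assay, at which 3 of the 3 values shown sit.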